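Compound 2 to compound 4: a step among limits

The source may hold more compounds than are shown below. What is called first, only, known or untested is meant among the compounds shown, and "the series" means these compounds.

In an ADME assay on HepG2 cells (Homo sapiens) for cytotoxicity, read by MTT assay, with a stated time of 72 h (a higher number here means that more compound is tolerated, a lower number that less compound is tolerated), compound 2 (`Nc1ccc(C#Cc2cc(Cl)cn3c([N+](=O)[O-])c(CS(=O)(=O)c4ccccc4)nc23)cc1`) gives > 3900 nM as a limit and not as a number. Compound 1 (`O=[N+]([O-])c1c(CS(=O)(=O)c2ccccc2)nc2c(C#Cc3ccccc3F)cc(Cl)cn12`) gives > 3900 nM as a limit too. Compound 3 (`O=[N+]([O-])c1c(CS(=O)(=O)c2ccccc2)nc2c(C#Cc3ccc(CO)cc3)cc(Cl)cn12`) gives > 15600 nM as a limit as well. Compound 2 therefore has no readable place in the series, whose values consist of the limit of > 3900 nM in this assay, at which 2 of the 3 values shown sit, and the limit of > 15600 nM in this assay, at which 1 of the 3 values shown sits, with no number among them.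

Compound 4 (`O=[N+]([O-])c1c(CS(=O)(=O)c2ccccc2)nc2c(C#CCCO)cc(Cl)cn12`) carries 2-hydroxyethyl in place of 4-aminophenyl on a triple-bonded carbon, a change counted as 2-hydroxyethyl in place of 4-aminophenyl on a triple-bonded carbon in full. All three measured compounds keep an aromatic ring at that place, so none of them shows this change directly.

The nearest evidence is a step that the two limits leave unreadable from compound 1 to compound 2 together with a step that the two limits leave unreadable from compound 1 to compound 3 and a step that the two limits leave unreadable from compound 2 to compound 3 and none of these has a readable size. No size can be carried over from them, and no fall in this assay is expected. The expected change is a step that the limit leaves unreadable from compound 2 to compound 4 and it remains a rough estimate. A further limit is the most likely report. For compound 4 the estimated value is 10000 nM with an expected range from 3900 nM to 30000 nM in this assay.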

Compound 4, half-maximal cytotoxic concentration: > 125000 nM
Compound 4: no number, only a limit (the forecaster's own chance of this, stated with the estimate: 80%); middle value at least 12-fold (1.09 log units) from the limit.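

In this assay compound 4 gives > 125000 nM, a limit and not a number. Among these compounds, compound 1, compound 2 and compound 3 also stand only as limits, so no step from any of them to compound 4 can be read. The compounds shown leave open whether 2-hydroxyethyl in place of 4-aminophenyl on a triple-bonded carbon changes the tolerated concentration at all.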